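This account rests on a few compounds, and the source may have more. Where it says the series, first, only, none or still open, it means among the compounds named here.

Working notes on the series.

The compounds share a core and differ in the substituents on the pendant aromatic ring. Compound 1 `COc1ccc(Cn2cc[nH]c2=S)cc1` carries a methoxy group; in an assay on isolated protein for inhibition of Dopamine beta-hydroxylase (Rattus norvegicus) (on this read-out higher numbers stand for weaker inhibition and lower numbers for stronger inhibition), compound 1 gives 204000 nM. Compound 2 `S=c1[nH]ccn1Cc1ccc(Br)cc1` carries a bromo group instead, and in this assay compound 2 gives 115000 nM. Compound 3 `S=c1[nH]ccn1Cc1cc(Cl)ccc1Cl` carries two chloro groups, and in this assay compound 3 gives 97700 nM. Among the three numbers measured, compound 1 stands highest; compound 2 is nearest, compound 3 furthest.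

Going by the values given here, the one single-point step measured so far is a 1.8-fold lower number from compound 1 to compound 2 (0.25 log units; within the scatter). It concerns an exchange of the group already present, not the addition of a further group, so it does not bear directly on the change considered here.

Compound 4 `COc1ccc(Cn2cc[nH]c2=S)cc1C` differs from compound 1 by methyl in place of hydrogen on an aromatic carbon, the new methyl sitting on an aromatic carbon of the six-membered aromatic ring of carbon only, ortho to the methoxy group and meta to the group of seven heavy atoms. Among the compounds with values here, no measured pair tests this kind of addition. Within the data shown here, with only the step to compound 2 as context, and that one within the scatter, no step beyond the scatter is expected in this assay; the expected step is a 1.1-fold lower number from compound 1 to compound 4 (0.05 log units; within the scatter).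

The estimate for compound 4 in this assay is therefore 180000 nM, expected to lie between 70000 nM and 450000 nM.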

Compound 4, half-maximal inhibitory concentration: 69200 nM
Beside the measured number, compound 4's estimate is 2.6-fold (0.42 log units) above it; measured number below the stated range.
By their numbers in this assay, from the lowest: compounds 4, 3, 2 and 1 (each within the scatter of the next, the first and the last beyond it).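

Methyl in place of hydrogen on an aromatic carbon, ortho to a methoxy group and meta to a group of 7 heavy atoms, is the first addition of a group to the pendant ring in this series, and in this assay it gives a 2.9-fold lower number from compound 1 to compound 4 (0.47 log units; beyond the scatter). Going by these compounds alone, this modest step lies beyond the scatter, whereas the only earlier single-place step, an exchange of the group already present, gave a 1.8-fold lower number from compound 1 to compound 2 (0.25 log units; within the scatter) and stayed within it, so this ring carbon is a place where a single added methyl moves the number downward in this assay. The data shown give no measured basis for explaining this step.

The compounds shown leave open whether the step depends on the methoxy group remaining in place, as the methyl is seen here only alongside that group. They also leave open how the number responds on the same ring carbon to another group, such as an ethyl group, an amine or a carboxylic acid, and whether any such group would take it lower than methyl does.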